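Swapping a Methoxymethyl for an Amide on the Ring

A few compounds are considered here, and "the series" means these few. Any claim that something is new, unique, unknown or untested is made for them only; others in the source may bear on it.

Compound 1 `COC/C1=C/C[C@](C)(CCC=C(C)C)/C=C/[C@@H](OC(=O)C=C(C)C)[C@](C)(OC)/C=C/C1=O`: 14600 nM
Compound 2 `COC/C1=C/C[C@](C)(CCC=C(C)C)/C=C/[C@@H](OC(=O)C=C(C)C)[C@](C)(O)/C=C/C1=O`: 3850 nM
Compound 3 `CC(C)=CCC[C@]1(C)/C=C/[C@@H](OC(=O)C=C(C)C)[C@](C)(O)/C=C/C(=O)/C(C[Si](c2ccccc2)(c2ccccc2)C(C)(C)C)=C\C1`: 20700 nM

All three were tested in a functional assay on SW480 cells (Homo sapiens) for antiproliferative activity, read by MTT assay, with a stated time of 48 h; a lower number here means a stronger inhibitor, a higher number a weaker inhibitor. Compound 2 gives the lowest number of the three, with compound 1 next and compound 3 furthest. Within the data shown here, the only measured step, a 3.8-fold lower number from compound 1 to compound 2 (0.58 log units; beyond the scatter), changes a different site. Among the measured compounds shown here, compound 3 carries another group at the ring carbon in question and shows a higher number than compound 2, but no step between them is given.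

Compound 4 `CC(C)=CCC[C@]1(C)/C=C/[C@@H](OC(=O)C=C(C)C)[C@](C)(O)/C=C/C(=O)/C(C(=O)N(C)C)=C\C1` differs from compound 2 by dimethylcarbamoyl in place of methoxymethyl on a double-bonded ring carbon. For the measured compounds named here, no measured step touches this position, so the evidence is thin. A modest weakening is expected for compound 4, a 1.7-fold higher number from compound 2 to compound 4 (0.23 log units; within the scatter). Compound 4 is therefore estimated at 6500 nM, within 2000 nM to 20000 nM.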

Compound 4, half-maximal inhibitory concentration: 3300 nM
Compound 4: the middle estimate sits 2.0-fold (0.29 log units) above what was measured; low and high end bracket the measured number.
By their numbers in this assay, from the lowest: compounds 4 and 2 (each within the scatter of the next); then compounds 1 and 3 (each within the scatter of the next).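

In this assay, among these compounds, dimethylcarbamoyl in place of methoxymethyl on the double-bonded ring carbon gives a 1.2-fold lower number from compound 2 to compound 4 (0.07 log units; within the scatter), the first measured step at this position. Here, a group with more heavy atoms that brings in nitrogen leaves the number within the scatter. Nothing available gives a reason why the two groups read alike.

As far as these compounds go, whether a carboxylic acid, an amine or a longer chain on this ring carbon would also stay within the scatter remains open. So does whether methyl in place of hydrogen on the hydroxy oxygen would weaken a compound that carries dimethylcarbamoyl.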